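This account rests on a few compounds, and the source may have more. Where it says the series, first, only, none or still open, it means among the compounds named here.

Working notes on the sulfonyl series.

Three compounds have numbers in a functional assay (Platelet, plasma) for inhibition, with Homo sapiens as the target; a lower number here means a stronger inhibitor, a higher number a weaker inhibitor. Compound 2 `N#Cc1cc2c(nc1N1CCC(C(=O)NS(=O)(=O)Cc3ccc(Cl)cc3)CC1)COC2=O` gives 4420 nM in this assay, the lowest of the three numbers. Compound 1 `CC1(C(=O)NS(=O)(=O)Cc2ccc(F)cc2F)CCN(c2nc3c(cc2C#N)C(=O)OC3)CC1` gives 8760 nM in this assay, a number within the scatter of that for compound 2, so no order between the two is claimed. Compound 3 `N#Cc1cc2c(nc1N1CCC(C(=O)NS(=O)(=O)Cc3ccccc3)CC1)CCCC2=O` gives 117000 nM in this assay, well beyond the scatter from compound 2; compound 3 also carries a different core and a plain benzyl on its sulfonyl sulfur, so its gap from compound 2 cannot be assigned to one feature.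

Compound 4 `CC(c1ccccc1)S(=O)(=O)NC(=O)C1CCN(c2nc3c(cc2C#N)C(=O)OC3)CC1` keeps the core and the acyl sulfonamide of compound 2 and changes the group on the sulfonyl sulfur: 1-phenylethyl in place of 4-chlorobenzyl on a sulfonyl sulfur. Among the measured compounds shown here, no measured pair isolates this change. The halogen-free benzyl-type group of compound 3 sits on another core, so it gives no clean guide; compound 1 shows that a different halogen pattern leaves the number near that of compound 2.

For compound 4 a modest weakening is expected, the step of a 2.3-fold higher number from compound 2 to compound 4 (0.35 log units; beyond the scatter). Compound 4 is estimated at 10000 nM in this assay, with a range from 3000 nM to 35000 nM.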

Compound 4, half-maximal inhibitory concentration: 4160 nM
Estimate against measurement, compound 4: 2.4-fold (0.38 log units) above; the measured number falls inside the stated range.
By their numbers in this assay, from the lowest: compounds 4, 2 and 1 (each within the scatter of the next, the first and the last beyond it); then compound 3.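

In this assay, among the compounds shown here, the first pair that differs in one place, 1-phenylethyl in place of 4-chlorobenzyl on a sulfonyl sulfur, gives a 1.1-fold lower number from compound 2 to compound 4 (0.03 log units; within the scatter) and so separates neither group from the other on the shared core. On this core, then, the chlorine of 4-chlorobenzyl is not needed to reach a number of this size, since a group of carbon only stands level with it, though this rests on these two groups alone. Nothing measured on the compounds gives a reason why the two groups stand level.

As far as these compounds go, both groups carry a six-membered aromatic ring of carbon only, so it remains open whether a group on the sulfonyl sulfur without that ring, such as a straight butyl chain, or a ring bearing an amine or a carboxylic acid, would move the number beyond the scatter. From the compounds shown here alone, it also remains open whether 1-phenylethyl and 4-chlorobenzyl would stand as close together on the core of compound 3.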